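Nitro on the Phenyl Ring of a Thiosemicarbazone

The source may report more compounds than this note shows. Statements on the series, on what has been measured and on what is new or still open speak of the compounds shown alone.

Measured compounds:
Compound 1 `CC1=CC[C@H](C(C)(C)NC(=S)N/N=C/c2ccc(O)cc2)CC1`: > 100000 nM
Compound 2 `COc1cc(/C=N/NC(=S)NC(C)(C)[C@H]2CC=C(C)CC2)ccc1O`: 63900 nM
Compound 3 `CC1=CC[C@H](C(C)(C)NC(=S)N/N=C(\C)c2ccccc2)CC1`: > 100000 nM

Of the compounds shown here, three sharing one core have been tested in a functional assay on MCF7 cells (Homo sapiens) for inhibition, read by sulforhodamine B assay, with a stated time of 48 h; on this read-out higher numbers stand for weaker inhibition of growth and lower numbers for stronger inhibition of growth. For compound 1 the value is a limit of the assay, > 100000 nM. Compound 2, which carries a methoxy group on an aromatic carbon, gives 63900 nM. Between these two lies the only step measured here, an at least 1.5-fold lower number from compound 1 to compound 2 (0.19 log units; that floor lies within the scatter), a change that stays within the usual scatter. For compound 3 the result is again a limit, > 100000 nM, so compound 3 sits where (the limit of > 100000 nM in this assay, at which 2 of the 3 values shown sit), together with compound 1.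

Compound 4 `CC1=CC[C@H](C(C)(C)NC(=S)N/N=C(\C)c2ccc([N+](=O)[O-])cc2)CC1` is the unmeasured partner of compound 3. The change is nitro in place of hydrogen on an aromatic carbon; nothing else moves. For the measured compounds named here, no measured step involves a nitro group, and the one step that is known, the methoxy step, was too small to count. There is therefore no basis to expect a shift beyond the scatter, and the estimated step of a number no higher from compound 3 to compound 4 (the limit leaves the size open) reflects that. Compound 4 is expected to give about 100000 nM in this assay, within a range from 35000 nM to 300000 nM, most likely reported only as a limit again.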

Compound 4, concentration for total growth inhibition: 77500 nM
Compound 4: middle estimate off by 1.3-fold (0.11 log units), on the high side, and the stated range covers the measured number.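

In this assay the swap of hydrogen for nitro on this aromatic carbon, para to a large group, turns a compound without a measured number into one with a real reading, so compound 4 joins compound 2 as a compound that can be placed on the scale. From the compounds shown here alone, the step is an at least 1.2-fold lower number from compound 3 to compound 4 (0.11 log units; that floor lies within the scatter) and this gives only a minimum size, which means that the nitro change cannot yet be told apart from ordinary variation between repeated measurements, and its true size remains unknown. The value of compound 3 is a limit and not a number, and that limit is what leaves the step open-ended: the limit of > 100000 nM in this assay, at which 2 of the 4 values shown sit.

The compounds shown leave open how an amine or a carboxylic acid on this same aromatic carbon would read, and whether any group placed there can move the number clearly beyond the usual scatter. They also leave open whether nitro would give a similar step on the ring of compound 1, where a hydroxyl group already sits.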